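The source may report more compounds than this note shows. Statements on the series, on what has been measured and on what is new or still open speak of the compounds shown alone.

Measured compounds:
Compound 1, `Cc1cn(C2CC(N=[N+]=[N-])C(COC(=O)NCCCN)O2)c(=O)[nH]c1=O`, in a functional assay on MT4 cells (Homo sapiens) for cytotoxicity (on this read-out lower numbers stand for higher toxicity in this test and higher numbers for lower toxicity in this test), gives > 50000 nM, a limit of the assay and not a number.
Compound 2, `Cc1cn(C2CC(N=[N+]=[N-])C(COC(=O)OCCCCCO)O2)c(=O)[nH]c1=O`, in this assay gives > 50000 nM, again a limit of the assay.
Compound 3, `Cc1cn(C2CC(N=[N+]=[N-])C(COC(=O)CCCC(=O)OC(C)(C)C)O2)c(=O)[nH]c1=O`, in this assay gives > 50000 nM, once more a limit of the assay.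

Compound 3 therefore stands where every measured compound stands: at the limit of > 50000 nM in this assay, at which 3 of the 3 values shown sit. No number separates it from compound 1 or compound 2, and the steps a step that the two limits leave unreadable from compound 1 to compound 3 and a step that the two limits leave unreadable from compound 2 to compound 3 remain unreadable, as does a step that the two limits leave unreadable from compound 1 to compound 2. The compound to be measured is compound 4, `Cc1cn(C2CC(N=[N+]=[N-])C(COC(=O)OCCCC(=O)O)O2)c(=O)[nH]c1=O`. It differs from compound 3 in one place: 3-carboxypropoxy in place of 3-(tert-butoxycarbonyl)propyl on a carbonyl carbon. The measured steps that touch this position all sit between limits, so none of them gives a size, in either direction, from which a change in this assay could be read. Within the data shown here, what the three measurements show is only that changes at this carbonyl carbon, across an amine, an alcohol-bearing chain and a tert-butyl ester, have left every compound at the limit. On that basis compound 4 is expected to remain at the limit as well, and the step that the limit leaves unreadable from compound 3 to compound 4 is estimated to be none that could be resolved. The estimate for compound 4 in this assay is 70000 nM, within 35000 nM to 200000 nM.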

Compound 4, half-maximal cytotoxic concentration: > 50000 nM
Compound 4 was reported as a limit; the forecaster's own chance of this, stated with the estimate: 85%; the middle value does not contradict the limit.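

Compound 4 in this assay gives > 50000 nM, a limit of the assay and not a number, and its steps from compound 1, compound 2 and compound 3 cannot be read. The compounds shown leave open how far any of the four lies beyond that limit, and whether any change on this carbonyl carbon would give a measurable value: the limit of > 50000 nM in this assay, at which 4 of the 4 values shown sit.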